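Moving from 3-hydroxyphenyl to 4-hydroxyphenyl in a cytotoxic series

This account rests on a few compounds, and the source may have more. Where it says the series, first, only, none or still open, it means among the compounds named here.

In a functional assay on MCF7 cells (Homo sapiens) for cytotoxicity, read by MTT assay, with a stated time of 72 h (on this read-out higher numbers stand for weaker inhibition and lower numbers for stronger inhibition), compound 1 `COc1ccc(/C=C2\CCC/C(=C\c3ccccc3Cl)C2=O)cc1OC` gives 10400 nM, and compound 2 `COc1ccc(/C=C2\CCC/C(=C\c3cccc(O)c3)C2=O)cc1OC` gives 2900 nM. Among the measured compounds shown here, compound 2 therefore holds the lower of the two numbers so far. For the measured compounds named here, the only measured step is a 3.6-fold lower number from compound 1 to compound 2 (0.55 log units; beyond the scatter), and it comes with 3-hydroxyphenyl in place of 2-chlorophenyl on a double-bonded chain carbon bound to a double-bonded ring carbon.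

Compound 3 `COc1ccc(/C=C2\CCC/C(=C\c3ccc(O)cc3)C2=O)cc1OC` shares its core with compound 2 and differs in that same place: 4-hydroxyphenyl in place of 3-hydroxyphenyl on a double-bonded chain carbon bound to a double-bonded ring carbon. Here 4-hydroxyphenyl stands in place of 3-hydroxyphenyl. Going by the values given here, the step to compound 2 bears on this change only indirectly, since it replaced a chlorinated ring with a hydroxylated one, and no measured pair compares two hydroxyphenyl groups. Among the compounds with values here, with only that modest step as a guide, no change beyond the scatter is expected in this assay, and no direction can be favoured. The expected step is a 1.1-fold lower number from compound 2 to compound 3 (0.03 log units; within the scatter). In this assay the estimated value for compound 3 is 2700 nM, with an expected range of 1000 nM to 7500 nM.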

Compound 3, half-maximal inhibitory concentration: 17000 nM
Estimate against measurement, compound 3: 6.3-fold (0.80 log units) below, outside the stated range (above it).
By their numbers in this assay, from the lowest: compound 2; then compounds 1 and 3 (each within the scatter of the next).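

At this place, on a double-bonded chain carbon bound to a double-bonded ring carbon, the two hydroxyphenyl groups are not interchangeable in this assay: 4-hydroxyphenyl in place of 3-hydroxyphenyl gives a 5.9-fold higher number from compound 2 to compound 3 (0.77 log units; beyond the scatter) even though the two groups have the same atoms and the same counts of hydrogen-bond donors and acceptors. The lower number of compound 2 therefore does not follow from having a hydroxyphenyl group as such, since 4-hydroxyphenyl in place of 2-chlorophenyl gives a 1.6-fold higher number from compound 1 to compound 3 (0.21 log units; within the scatter) and leaves compound 3 within the scatter of compound 1. Among these three compounds, only compound 2 stands apart, and what separates it from compound 3 is how the same atoms are joined, while nothing at hand explains why this arrangement matters in these cells.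

On these data alone, what remains open is whether 2-hydroxyphenyl would follow compound 2 or compound 3, and whether 3-methoxyphenyl or 3-aminophenyl at this place would keep the number of compound 2. As far as these compounds go, it is also open whether the same difference between 3-hydroxyphenyl and 4-hydroxyphenyl would hold if the 3,4-dimethoxyphenyl group on the other side of the core were replaced by a plain phenyl group.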